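Aminoamino for Hydroxy on the Carbonyl Carbon of Compound 2

The compounds below may be only part of what the source reports. "The series", "measured", "known", "first", "only" and "open" are said of these compounds alone.

Compound 2 `Nc1c(C(=O)O)sc2ncccc12` is one of three compounds tested in an assay on isolated protein for inhibition of LIM domain kinase 1 (Homo sapiens), read by Kinase-Glo, with a stated time of 60 min; a higher number here means a weaker inhibitor, a lower number a stronger inhibitor. In this assay compound 2 gives > 100000 nM, which is a limit of the assay rather than a number. Compound 1 `NC(=O)c1sc2ccccc2c1O` likewise gives a limit, > 100000 nM. Among the measured compounds shown here, compound 3 `CNc1c(C(N)=O)sc2ccccc12` gives 34000 nM, and the one measured step, an at least 2.9-fold lower number from compound 1 to compound 3 (0.46 log units; beyond the scatter), changes a group on an aromatic carbon, not on the carbonyl carbon. Compound 4 `NNC(=O)c1sc2ncccc2c1N` differs from compound 2 by the change (aminoamino in place of hydroxy on a carbonyl carbon). For the measured compounds named here, no measured step touches this position, so the only guide is that compound 2 sits at the limit of > 100000 nM in this assay, at which 2 of the 3 values shown sit. For compound 4 the expected step is an at least 1.2-fold lower number from compound 2 to compound 4 (0.09 log units; that floor lies within the scatter), small at best. Compound 4 is therefore estimated at 80000 nM, between 20000 nM and 300000 nM.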

Compound 4, half-maximal inhibitory concentration: > 100000 nM
Compound 4 gave a limit, no number; the forecaster's own chance of this, stated with the estimate: 60%; middle value at least 1.2-fold (0.09 log units) away from the limit.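

Among the compounds shown here, compound 2 and compound 4 both give a limit rather than a number, so no step between them can be read: the limit of > 100000 nM in this assay, at which 3 of the 4 values shown sit. From the compounds shown here alone, whether aminoamino in place of hydroxy on this carbonyl carbon changes inhibition at all remains open.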